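The source may report more compounds than this note shows. Statements on the series, on what has been measured and on what is new or still open speak of the compounds shown alone.

Compound 1 `CCCOc1ccc(CN(Cc2ccc(C(C)(C)C)cc2)Cc2cc3cc(C)ccc3[nH]c2=O)cc1`: in a toxicity assay on MDCK cells (Canis lupus familiaris) for cytotoxicity, read by crystal violet staining, with a stated time of 48 h (on this read-out higher numbers stand for lower toxicity in this test and lower numbers for higher toxicity in this test), compound 1 gives > 5000 nM, which is a limit of the assay and not a number.
Compound 2 `Cc1ccc2[nH]c(=O)c(CN(Cc3ccc(C(C)(C)C)cc3)[C@@H](C)c3ccc(F)cc3)cc2c1`: in this assay compound 2 gives > 5000 nM, again a limit and not a number.

Compound 2 therefore stands at the limit of the assay, as does compound 1, and the step that the two limits leave unreadable from compound 1 to compound 2 cannot be read because of the limit of > 5000 nM in this assay, at which 2 of the 2 values shown sit.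

Compound 3 `Cc1ccc2[nH]c(=O)c(CN(Cc3ccc(C(C)(C)C)cc3)[C@H](C)c3ccc(F)cc3)cc2c1` is the mirror-image partner of compound 2: the two compounds have the same atoms and bonds and differ only in configuration as drawn: 1 of 1 stereo elements differ; a stereocentre at a saturated chain carbon is drawn S in compound 2 and R in compound 3. Within the data shown here, no measured step bears on a change of configuration alone, and the only measured step is itself unreadable. Both measured compounds sit at the same limit, so no step beyond the usual scatter is expected from compound 2 to compound 3, and compound 3 is expected most likely to return a limit as well; the estimated step is a step that the limit leaves unreadable from compound 2 to compound 3. For compound 3 the estimate in this assay is 8000 nM, within 3000 nM to 30000 nM.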

Compound 3, half-maximal cytotoxic concentration: > 5000 nM
Compound 3 was reported as a limit (the forecaster's own chance of this, stated with the estimate: 85%); the middle value does not contradict the limit.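

Compound 3 gives > 5000 nM in this assay, again a limit and not a number, so neither of its steps from compound 1 and compound 2 can be read: the limit of > 5000 nM in this assay, at which 3 of the 3 values shown sit.

The compounds shown leave open whether the mirror-image partners compound 2 and compound 3 differ in cytotoxicity at all.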